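A few compounds are considered here, and "the series" means these few. Any claim that something is new, unique, unknown or untested is made for them only; others in the source may bear on it.

Working notes on the series. Among the compounds with values here, compound 1 `CN(C)C(=O)c1cc2cnc(Nc3ccc(NC(=O)C4(C(=O)Nc5ccccc5F)CC4)cc3)nc2n1C1CCCC1` is the reference point; in a functional assay on A549 cells (Homo sapiens) for inhibition, read by CCK-8 assay, with a stated time of 72 h, tested at 1 uM (on this read-out lower numbers stand for less inhibition of growth and higher numbers for more inhibition of growth at the one concentration tested), compound 1 gives 79.1%, the higher of the two numbers measured so far. Compound 2 `CN(C)C(=O)c1cc2cnc(Nc3ccc(NC(=O)C4(C(=O)Nc5cccc(Br)c5)CC4)cc3)nc2n1C1CCCC1` carries 3-bromophenyl in place of 2-fluorophenyl on the amide-type nitrogen, and in this assay compound 2 gives 20.2%; the step of a number 58.9 percentage points lower from compound 1 to compound 2 (beyond the scatter) is beyond the scatter and large.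

Compound 3 `CN(C)C(=O)c1cc2cnc(Nc3ccc(NC(=O)C4(C(=O)Nc5ccc(C#N)cc5)CC4)cc3)nc2n1C1CCCC1` is not yet measured. It differs from compound 1 by 4-cyanophenyl in place of 2-fluorophenyl on an amide-type nitrogen. Within the data shown here, the only step that bears on this change is the one from compound 1 to compound 2, where replacing 2-fluorophenyl on the same amide-type nitrogen cost much of the growth inhibition. As far as these compounds go, because of a number 58.9 percentage points lower from compound 1 to compound 2 (beyond the scatter) a drop beyond the scatter is expected for compound 3 as well, though the 4-cyanophenyl group is untested and the size is uncertain. For compound 3 in this assay the expected value is 40%, with a range of 10% to 75%, corresponding to the estimated step of a number 39.1 percentage points lower from compound 1 to compound 3 (beyond the scatter).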

Compound 3, percent growth inhibition at one concentration: 86.1%
Compound 3: middle estimate off by 46.1 percentage points, on the low side, and the stated range ends below it.
By their numbers in this assay, from the lowest: compound 2; then compounds 1 and 3 (each within the scatter of the next).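

In this assay, 4-cyanophenyl can take the place of 2-fluorophenyl on the amide-type nitrogen with no change beyond the scatter: a number 7 percentage points higher from compound 1 to compound 3 (within the scatter). Losing 2-fluorophenyl therefore does not in itself cost growth inhibition, so the loss seen with compound 2 is tied to 3-bromophenyl and not to every replacement at this place, as a number 65.9 percentage points higher from compound 2 to compound 3 (beyond the scatter) shows. Nothing available accounts for the gap between these groups.

The compounds shown leave open whether the low number of compound 2 follows the bromine or where it sits on the ring, a question that 4-bromophenyl and 3-cyanophenyl would address. Also open, as far as these compounds go, is whether the aromatic ring is needed at all, which cyclohexyl in its place would test.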